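Fluoro for methoxy on the aryl of compound 1

This account rests on a few compounds, and the source may have more. Where it says the series, first, only, none or still open, it means among the compounds named here.

Compound 1 `COc1ccc(C2=NN(c3ccc(S(C)(=O)=O)cc3)C(=O)CC2)cc1` gives the highest of three numbers in a functional assay on the whole organism (strain Wistar) for inhibition, with Rattus norvegicus as the target, read by paw edema, with stated times of 30 min and 5 h, at a dose of 0.05 mmol/kg by the oral route (on this read-out higher numbers stand for more inhibition at the one dose given (going by the name of the read-out) and lower numbers for less inhibition), with 68.4%, though only one of the other two sits beyond the scatter from it. Compound 2 `CS(=O)(=O)c1ccc(N2N=C(c3ccc(Oc4ccccc4)cc3)CCC2=O)cc1` gives 65.7%, and the step of a number 2.7 percentage points lower from compound 1 to compound 2 (within the scatter) changes the methoxy into a phenoxy without moving the number meaningfully. Compound 3 `CS(=O)(=O)c1ccc(N2N=C(c3ccc(O)c(Cl)c3)CCC2=O)cc1` gives 55.2%, and the step of a number 13.2 percentage points lower from compound 1 to compound 3 (beyond the scatter) replaces the whole 4-methoxyphenyl and costs a modest amount. Compound 4 `CS(=O)(=O)c1ccc(N2N=C(c3ccc(F)cc3)CCC2=O)cc1` has not been measured; it differs from compound 1 by fluoro in place of methoxy on an aromatic carbon. Both measured steps touch the same part of the structure: altering the methoxy itself left the number essentially unchanged, while exchanging the substituted phenyl lowered it modestly. Compound 4 is therefore expected to lie near compound 1 or slightly below it, with a step of a number 8.4 percentage points lower from compound 1 to compound 4 (within the scatter). Compound 4 is estimated to give 60% in this assay, between 47% and 72%.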

Compound 4, a percentage reported as inhibition, in the whole organism at one dose (the size of the read-out at that dose, not a potency): 73.6%
The estimate for compound 4 lay 13.6 percentage points below the measured number; measured number above the stated range.
By their numbers in this assay, from the lowest: compound 3; then compounds 2, 1 and 4 (each within the scatter of the next).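

Among these compounds, at this aromatic carbon, para to a large group, the oxygen of the earlier compounds proves dispensable in this assay: fluoro in place of methoxy gives a number 5.2 percentage points higher from compound 1 to compound 4 (within the scatter) and fluoro in place of phenoxy gives a number 7.9 percentage points higher from compound 2 to compound 4 (within the scatter) so that a single fluorine holds the number level with both ethers. Among the compounds shown here, the only new step to leave the scatter is a number 18.4 percentage points higher from compound 3 to compound 4 (beyond the scatter) but it exchanges the whole 3-chloro-4-hydroxyphenyl for 4-fluorophenyl, so it cannot separate the share of the chloro from that of the hydroxy. Nothing available explains why these numbers fall as they do.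

From the compounds shown here alone, it remains open whether an amine, a nitrile or a longer chain at this place would keep the number in the same range. Also open, going by these compounds, is how chloro or hydroxy alone on the phenyl would read.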